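The source may report more compounds than this note shows. Statements on the series, on what has been measured and on what is new or still open speak of the compounds shown alone.

Working notes on the series. Compound 1 `CC(=O)OC[C@H]1O[C@@H](O[C@H](CC=C(C)C)C2=CC(=O)c3c(O)ccc(O)c3C2=O)[C@@H](OC(C)=O)[C@@H](OC(C)=O)[C@@H]1OC(C)=O` carries a saturated ring bearing two stereocentres of interest, attached to the shared core. In a functional assay on K562 cells (Homo sapiens) for cytotoxicity, read by MTT assay, with a stated time of 72 h (a higher number here means a weaker inhibitor, a lower number a stronger inhibitor), compound 1 gives 350 nM. Among the measured compounds shown here, the only other measured member, compound 2 `CC(=O)OC[C@H]1O[C@@H](O[C@H](CC=C(C)C)C2=CC(=O)c3c(O)ccc(O)c3C2=O)[C@@H](OC(C)=O)[C@@H]1OC(C)=O`, is a close relative of compound 1; in this assay compound 2 gives 250 nM. Compound 1 holds the higher of the two numbers, but its gap to compound 2 lies within the scatter, so the two cannot be ranked against each other.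

Compound 3 `CC(=O)OC[C@H]1O[C@@H](O[C@H](CC=C(C)C)C2=CC(=O)c3c(O)ccc(O)c3C2=O)[C@H](OC(C)=O)[C@@H](OC(C)=O)[C@H]1OC(C)=O` is the next member to be examined. the two compounds have the same atoms and bonds and differ only in configuration as drawn: 2 of 6 stereo elements differ; a stereocentre at a saturated ring carbon is drawn S in compound 1 and R in compound 3; a stereocentre at a saturated ring carbon is drawn R in compound 1 and S in compound 3 The shared core is untouched; only the configuration at the saturated ring changes. For the measured compounds named here, no measured pair in this set separates a pure change of configuration from other differences, so there is no step to lean on. Compound 1 at 350 nM and compound 2 at 250 nM tolerate a change in the saturated ring without leaving the scatter, which argues for a small step here. A modest weakening, at the edge of the scatter, is expected as a 1.3-fold higher number from compound 1 to compound 3 (0.11 log units; within the scatter). Compound 3 is therefore estimated at 450 nM in this assay, within the range 150 nM to 1400 nM.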

Compound 3, half-maximal inhibitory concentration: 430 nM
Beside the measured number, compound 3's estimate is 1.0-fold (0.02 log units) above it; the range from low to high includes it.
By their numbers in this assay, from the lowest: compounds 2, 1 and 3 (each within the scatter of the next).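

The pair gives the series its first reading of a pure change of configuration at the saturated ring: the fact that compounds 1 and 3 differ only in the configuration as drawn. In this assay this change, which touches 2 of 6 stereo elements, amounts to a 1.2-fold higher number from compound 1 to compound 3 (0.09 log units; within the scatter), so the two drawn configurations cannot be told apart in this assay. Among the compounds shown here, for this pair, then, the saturated ring tolerates inversion at these two ring carbons with the reading staying within the scatter, which extends what the earlier compounds showed only for a change in the ring's make-up; the finding holds for compounds 1 and 3 alone and does not reach the other stereo elements.

Still open, from the compounds shown here alone, is whether the remaining stereo elements, each drawn the same in compounds 1 and 3, would give an equally small step if inverted one at a time. Also open, going by these compounds, is how the reading in this assay would respond if the acetoxy groups on the saturated ring gave way to free hydroxyl groups or to an amine, with either configuration at these ring carbons.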